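Compound 2 to compound 3: one ring substituent changes

This account rests on a few compounds, and the source may have more. Where it says the series, first, only, none or still open, it means among the compounds named here.

Measured so far:
compound 1 `O=C1OCC[C@@H]1NC(=S)SCCOc1cccc2ccccc12` gives > 64000 nM
compound 2 `COc1ccccc1/C=C/C(=O)c1ccc(OCC(=O)N[C@H]2CCOC2=O)cc1` gives 10100 nM

Both were tested in a functional assay on DU-145 cells (Homo sapiens) for antiproliferative activity, read by MTT assay, with a stated time of 72 h; a lower number here means a stronger inhibitor, a higher number a weaker inhibitor. The value of compound 1 is a limit of the assay rather than a number, as shown by the limit of > 64000 nM in this assay, at which 1 of the 2 values shown sits. Among the compounds with values here, compound 2 therefore holds the only actual number in this assay, and its value, 10100 nM, is the only anchor for any expectation.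

Compound 3 `O=C(COc1ccc(C(=O)/C=C/c2cccc(F)c2)cc1)N[C@H]1CCOC1=O` has not yet been measured. It differs from compound 2 in one place: 3-fluorophenyl in place of 2-methoxyphenyl on a double-bonded chain carbon bound to a double-bonded chain carbon. The rest of the shared core, with its lactone-bearing amide and the ether-linked aryl ketone, is unchanged.

Within the data shown here, no step between measured compounds is available, so the size of this change can only be guessed from the single number of compound 2. A swap of one small substituent on a terminal aromatic ring is expected to move potency only modestly, if at all. The step of a 1.0-fold lower number from compound 2 to compound 3 (0.00 log units; within the scatter) is therefore expected to stay within the usual scatter. Compound 3 is expected to give 10000 nM in this assay, with a likely range of 3000 nM to 35000 nM.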

Compound 3, half-maximal inhibitory concentration: 17200 nM
For compound 3 the middle estimate is 1.7-fold (0.24 log units) below the measured one; measured number inside the range.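

In this assay, putting 3-fluorophenyl in place of 2-methoxyphenyl on a double-bonded chain carbon bound to a double-bonded chain carbon gives a 1.7-fold higher number from compound 2 to compound 3 (0.23 log units; within the scatter) and so does not separate the two compounds. Within the data shown here, this is the first reading at this position, and it shows that the two aromatic end groups give numbers that cannot be told apart, even though the leaving group holds one hydrogen-bond acceptor and the entering group holds none. No measurement shown offers an explanation for this result.

As far as these compounds go, the swap alters both the substituent and its printed ring position, so the contribution of each remains unknown: 3-methoxyphenyl or 2-fluorophenyl would be needed to separate them. From the compounds shown here alone, it also remains open whether a quite different group on this ring, such as an amine or a carboxylic acid, would move the number beyond the usual scatter of repeated measurements.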